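The source may hold more compounds than are shown below. What is called first, only, known or untested is meant among the compounds shown, and "the series" means these compounds.

Compound 1 `CCCc1nc2c(C)cc(C(=O)N3CCCCC3)cc2n1Cc1ccc(-c2ccccc2C(=O)O)cc1` gives 42 nM in an assay on isolated protein for displacement of a labelled ligand from Type-2 angiotensin II receptor (Homo sapiens), with a stated time of 180 min; on this read-out higher numbers stand for weaker inhibition and lower numbers for stronger inhibition.
Compound 2 `CCCc1nc2c(C)cc(NC(=O)CC)cc2n1Cc1ccc(-c2ccccc2C(=O)O)cc1` gives 78 nM in this assay.
Compound 3 `CCCc1nc2c(C)cc(NC(=O)c3ccccc3)cc2n1Cc1ccc(-c2ccccc2C(=O)O)cc1` gives 6 nM in this assay.

Compound 3 stands lowest of the three: the steps of a 7.0-fold lower number from compound 1 to compound 3 (0.85 log units; beyond the scatter) and a 13-fold lower number from compound 2 to compound 3 (1.11 log units; beyond the scatter) both lie beyond the scatter, so it is the strongest binder shown. Compound 4 `CCCc1nc2c(C)cc(NC(=O)c3ccc(C)cc3)cc2n1Cc1ccc(-c2ccccc2C(=O)O)cc1` differs from compound 3 by methyl in place of hydrogen on an aromatic carbon. Among the compounds with values here, none of the measured steps touches this part of the molecule; they exchanged the whole group on the amide side, whereas here the benzamido ring keeps its shape and only gains a methyl. With no measured guide, the step expected in this assay is one within the scatter, no change at the digits printed from compound 3 to compound 4 (within the scatter). Compound 4 is therefore estimated at 6 nM, with a range from 2 nM to 18 nM.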

Compound 4, half-maximal inhibitory concentration: > 10000 nM
Compound 4: no number, only a limit; the forecaster's own chance of this, stated with the estimate: 0%; middle value at least 1600-fold (3.22 log units) away from the limit.
By their numbers in this assay, from the lowest: compound 3; then compounds 1 and 2 (each within the scatter of the next). At a limit, above all of these: compound 4.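

Adding one methyl to the phenyl ring of the benzamido group, para to a large group, is a very small change, yet this assay gives an at least 1600-fold higher number from compound 3 to compound 4 (3.22 log units; beyond the scatter). The earlier steps shown here exchanged whole groups, while this one shows that a single added carbon can outweigh them, with an at least 120-fold higher number from compound 2 to compound 4 (2.10 log units; beyond the scatter) and an at least 230-fold higher number from compound 1 to compound 4 (2.37 log units; beyond the scatter). The value of compound 4 is a limit, not a number: the limit of > 10000 nM in this assay, at which 1 of the 4 values shown sits.

The compounds shown leave open whether this loss is specific to methyl. A fluorine, a methoxy or a carboxylic acid at this ring position could separate the two cases.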